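Working notes: aryl change on compound 2

The source may hold more compounds than are shown below. What is called first, only, known or untested is meant among the compounds shown, and "the series" means these compounds.

Measured in a functional assay on MCF7 cells (Homo sapiens) for inhibition, read by CCK-8 assay, with a stated time of 48 h; on this read-out higher numbers stand for weaker inhibition of growth and lower numbers for stronger inhibition of growth:
- compound 1 `CN1CCN(c2ccc(Nc3ncc(Cl)c(NCc4ccc(C(F)(F)F)cc4)n3)nc2)CC1`: 28400 nM
- compound 2 `CCc1ccc(Nc2nc(Nc3ccc(N4CCN(C)CC4)cn3)ncc2Cl)cc1`: 8230 nM

Of the two numbers in this assay, compound 2 holds the lower, at 8230 nM. Compound 3 `COc1cccc(Nc2nc(Nc3ccc(N4CCN(C)CC4)cn3)ncc2Cl)c1` differs from it by 3-methoxyphenyl in place of 4-ethylphenyl on a nitrogen on an aromatic ring, with 3-methoxyphenyl in place of 4-ethylphenyl on a nitrogen on an aromatic ring. Among the measured compounds shown here, the only measured step, a 3.5-fold lower number from compound 1 to compound 2 (0.54 log units; beyond the scatter), also falls at this place. It involves a different pair of groups, so it suggests a modest size at most and no direction for this change. The expected result is a 1.2-fold higher number from compound 2 to compound 3 (0.06 log units; within the scatter), with no clear shift beyond the scatter. Compound 3 is estimated at 9500 nM (expected range 3500 nM to 26000 nM).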

Compound 3, concentration for 50% growth inhibition: 7540 nM
Compound 3: the middle estimate sits 1.3-fold (0.10 log units) above what was measured; measured number inside the range.
By their numbers in this assay, from the lowest: compounds 3 and 2 (each within the scatter of the next); then compound 1.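

In this assay, the change at this nitrogen gives a 1.1-fold lower number from compound 2 to compound 3 (0.04 log units; within the scatter), so 3-methoxyphenyl and 4-ethylphenyl cannot be told apart here, even though the entering group carries a hydrogen-bond acceptor and the leaving group none. The second aryl group also reads a 3.8-fold lower number from compound 1 to compound 3 (0.58 log units; beyond the scatter), so both replacements of 4-(trifluoromethyl)benzyl at this place give lower numbers. No measured evidence accounts for either step. Still open, from the compounds shown here alone, is whether an amine or a carboxylic acid on this phenyl ring would move the number beyond the scatter.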